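A Fluoro Substitution Seen Twice Across Two Cores

The source may report more compounds than this note shows. Statements on the series, on what has been measured and on what is new or still open speak of the compounds shown alone.

Measured compounds:
compound 1, `Cn1cnc2c(Sc3ccccc3)ncnc21`: 6%
compound 2, `Cn1cnc2c(Sc3ccc(F)cc3)ncnc21`: 6%
compound 3, `Clc1ncnc2c1ncn2Cc1ccccc1`: 3%

In an assay on isolated protein for inhibition of Rho-associated protein kinase 1 (Homo sapiens), tested at 30 uM (a lower number here means less inhibition, a higher number more inhibition at the concentration tested (going by the name of the read-out)), compound 1 gives 6%. Compound 2 carries the change (fluoro in place of hydrogen on an aromatic carbon), and in this assay the result is no change at the digits printed from compound 1 to compound 2 (within the scatter). Compound 3, which has a different core, gives 3% in this assay; the difference between the two cores is not broken down here. All three measured values lie within the usual scatter of one another, so none of them can be set apart from the others.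

Compound 4, `Fc1ccc(Cn2cnc3c(Cl)ncnc32)cc1`, is not yet measured. It differs from compound 3 by fluoro in place of hydrogen on an aromatic carbon, the same change that leads from compound 1 to compound 2, at a place described in the same words. Because that earlier step was no change at the digits printed from compound 1 to compound 2 (within the scatter), the step from compound 3 to compound 4 in this assay is expected to be a number 1 percentage points higher from compound 3 to compound 4 (within the scatter). Compound 4 is therefore estimated to give 4% in this assay, most likely between -3% and 12%.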

Compound 4, a percentage reported as inhibition, at one concentration (the size of the read-out at that concentration, not a potency): 0%
The estimate for compound 4 lay 4 percentage points above the measured number, and the stated range covers the measured number.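

In this assay, the second case of fluoro in place of hydrogen on an aromatic carbon gives a number 3 percentage points lower from compound 3 to compound 4 (within the scatter). Set beside the first case, the change reads the same on the two cores: the same change on two cores in this assay, no change at the digits printed (within the scatter) from compound 1 to compound 2 and a number 3 percentage points lower (within the scatter) from compound 3 to compound 4, 3 percentage points apart, within the scatter of two such steps. Going by these compounds alone, this shows only that, on these two cores, the change left the read-out within the scatter in both cases; it does not show that the change has any real effect on inhibition, nor that a step of clear size would carry from one core to another, since neither step can be told from repeat variation and only two cores are represented.

The compounds shown leave open whether a different group at the same place, such as an amine or a carboxylic acid, would move the number beyond the scatter in this assay. They also leave open how the fluoro change would behave on a compound with a clearly higher reading, where a step of real size could be seen.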